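Replacing the benzyl group of compound 2

A few compounds are considered here, and "the series" means these few. Any claim that something is new, unique, unknown or untested is made for them only; others in the source may bear on it.

Compounds measured so far in a functional assay on MDA-MB-231 cells (Homo sapiens) for cytotoxicity, read by MTT assay, with a stated time of 72 h (on this read-out lower numbers stand for stronger inhibition and higher numbers for weaker inhibition), are these:
- compound 1 `CCN(CC)Cc1ccc2nc(NC(=O)N/N=C/c3cn(Cc4ccc(C(C)(C)C)cc4)c4ccccc34)sc2c1` gives 2120 nM
- compound 2 `CN(C)Cc1ccc2nc(NC(=O)N/N=C/c3cn(Cc4ccccc4Cl)c4ccccc34)sc2c1` gives 1180 nM
- compound 3 `CC1CCN(Cc2ccc3nc(NC(=O)N/N=C/c4cn(Cc5ccc(Cl)cc5Cl)c5ccccc45)sc3c2)CC1` gives 3140 nM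

Compound 2 with its 1180 nM stands within the scatter of compound 1, while compound 3 lies beyond the scatter of compound 2, on the higher side.

Compound 4 `CN(C)Cc1ccc2nc(NC(=O)N/N=C/c3cn(Cc4ccc(C(C)(C)C)cc4)c4ccccc34)sc2c1` has not yet been measured. Its change from compound 2 is 4-(tert-butyl)phenyl in place of 2-chlorophenyl on a saturated chain carbon bound to an aromatic nitrogen on a saturated chain carbon bound to an aromatic nitrogen, so 2-chlorobenzyl gives way to 4-(tert-butyl)benzyl.

Within the data shown here, no measured pair isolates this change, so the data give no direct step size. Compound 1 already carries 4-(tert-butyl)benzyl and differs from compound 4 elsewhere. The value of compound 1, 2120 nM, stays within the scatter of compound 2. The estimated 1.4-fold higher number from compound 2 to compound 4 (0.16 log units; within the scatter) is therefore a small one toward a higher number and is expected to stay within the usual scatter. For compound 4 the estimate is 1700 nM with an expected range from 850 nM to 3400 nM in this assay.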

Compound 4, half-maximal inhibitory concentration: 2230 nM
Compound 4: the middle estimate sits 1.3-fold (0.12 log units) below what was measured, and the stated range covers the measured number.
By their numbers in this assay, from the lowest: compounds 2, 1, 4 and 3 (each within the scatter of the next, the first and the last beyond it).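

In this assay, among these compounds, 4-(tert-butyl)phenyl in place of 2-chlorophenyl on a saturated chain carbon bound to an aromatic nitrogen gives a 1.9-fold higher number from compound 2 to compound 4 (0.28 log units; within the scatter) and so gives the first direct reading at this position, a step that stays within the scatter. Dimethylamino in place of diethylamino on a saturated chain carbon bound to an aromatic carbon gives a 1.1-fold higher number from compound 1 to compound 4 (0.02 log units; within the scatter) and so also stays within the scatter, with 4-(tert-butyl)benzyl held constant. No measured property bears on either step, and neither can be explained from these data.

Still open, on these data alone, is whether a pyridylmethyl group or a benzyl group carrying a carboxylic acid in place of 2-chlorobenzyl would move the number beyond the scatter. Also open, as far as these compounds go, is how a morpholine in place of dimethylamino would read in this assay on this series.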